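Chloro for Fluoro on the Benzyl Ring: Clearance Outlook

The compounds below may be only part of what the source reports. "The series", "measured", "known", "first", "only" and "open" are said of these compounds alone.

Compound 1 `Fc1cc(C(F)(F)F)ccc1-c1ccc(Cn2nnc3ccccc32)cc1` gives 1.2 mL/min/g in an ADME assay on microsomes from liver (Mus musculus, strain NMRI) for metabolic stability, tested at 2.5 uM; on this read-out lower numbers stand for slow clearance and higher numbers for fast clearance.
Compound 2 `FC(F)(F)c1ccc(-c2ccc(Cn3nnc4ccccc43)cc2)c(Cl)c1` gives 0.4 mL/min/g in this assay.
Compound 3 `Fc1ccc(Cn2nnc3c(Br)cccc32)cc1` gives 1 mL/min/g in this assay.

The change from compound 1 to compound 2 is chloro in place of fluoro on an aromatic carbon and produced a 3.0-fold lower number from compound 1 to compound 2 (0.48 log units; beyond the scatter). Compound 4 `Clc1ccc(Cn2nnc3c(Br)cccc32)cc1` is not yet measured; it arises from compound 3 by chloro in place of fluoro on an aromatic carbon. The difference between the cores of compound 1 and compound 3 is not broken down here. The surroundings also differ: in compound 1 the site is ortho to a large group and meta to a trifluoromethyl group (4 heavy atoms), in compound 3 it is para to a large group, so this is the same kind of change, not the same one. Because the earlier step of a 3.0-fold lower number from compound 1 to compound 2 (0.48 log units; beyond the scatter) was modest and beyond the scatter, a comparable step of a 2.0-fold lower number from compound 3 to compound 4 (0.30 log units; within the scatter) is expected in this assay, tempered for the changed surroundings. Compound 4 is expected at 0.5 mL/min/g, likely between 0.2 mL/min/g and 1.2 mL/min/g.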

Compound 4, intrinsic clearance in a liver preparation (reported as CLH), per the amount of preparation that the assay uses: 2 mL/min/g
The estimate for compound 4 lay 4.0-fold (0.60 log units) below the measured number, outside the stated range (above it).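

In this assay, chloro in place of fluoro on an aromatic carbon did not carry over unchanged from one core to the other, and the two steps differ: the same change on two cores in this assay, a 3.0-fold lower number (0.48 log units; beyond the scatter) from compound 1 to compound 2 and a 2.0-fold higher number (0.30 log units; within the scatter) from compound 3 to compound 4, 6.0-fold (0.78 log units) apart, beyond the scatter of two such steps. The new step, a 2.0-fold higher number from compound 3 to compound 4 (0.30 log units; within the scatter), is no larger than repeated measurements would give, so the drop seen on the other core did not recur here. With a single pair on each core, the data do not show whether the core or the surroundings of the site account for the gap, nor which way the change would go on a further core.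

The compounds shown leave open how a nitrile or an amine would behave in that same place. They also leave open whether a methoxy group there would give a step like either of these two.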